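Aryl swap on the shared core: outlook for compound 4

The source may report more compounds than this note shows. Statements on the series, on what has been measured and on what is new or still open speak of the compounds shown alone.

Measured compounds in a functional assay on HCT-116 cells (Homo sapiens) for antiproliferative activity, read by MTT assay, with a stated time of 48 h; on this read-out higher numbers stand for weaker inhibition and lower numbers for stronger inhibition:
compound 1, `N#CC1=C(N)Oc2c(c3nc4ccccc4nc3c3ccccc23)C12C(=O)N(Cc1cnnn1-c1cccc(Cl)c1)c1ccccc12`, gives > 50000 nM.
compound 2, `N#CC1=C(N)Oc2c(c3nc4ccccc4nc3c3ccccc23)C12C(=O)N(Cc1cnnn1-c1cccc(Br)c1)c1ccccc12`, gives > 50000 nM.
compound 3, `N#CC1=C(N)Oc2c(c3nc4ccccc4nc3c3ccccc23)C12C(=O)N(Cc1cnnn1-c1ccc([N+](=O)[O-])cc1)c1ccccc12`, gives > 50000 nM.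

Each of these three values is a limit of this assay, not a number, as stated by the limit of > 50000 nM in this assay, at which 3 of the 3 values shown sit. Compound 1 therefore stands only at a limit, and nothing places it relative to compound 2 or compound 3. The steps a step that the two limits leave unreadable from compound 1 to compound 2, a step that the two limits leave unreadable from compound 1 to compound 3 and a step that the two limits leave unreadable from compound 2 to compound 3 remain unreadable because of the limit of > 50000 nM in this assay, at which 3 of the 3 values shown sit; they show only that bromo in place of chloro, or 4-nitrophenyl in place of 3-chlorophenyl or 3-bromophenyl, did not bring any compound within range.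

Compound 4, `CC(=O)Nc1ccc(-n2nncc2CN2C(=O)C3(C(C#N)=C(N)Oc4c3c3nc5ccccc5nc3c3ccccc43)c3ccccc32)cc1`, differs from compound 1 thus: 4-acetamidophenyl in place of 3-chlorophenyl on an aromatic nitrogen. The measured steps that bear on it are the two aryl exchanges on the aromatic nitrogen, a step that the two limits leave unreadable from compound 1 to compound 3 and a step that the two limits leave unreadable from compound 2 to compound 3, both unreadable. Going by the values given here, no measured step gives a size or direction for a further aryl exchange. The step of a number no higher from compound 1 to compound 4 (the limit leaves the size open) is expected to be no readable change. Compound 4 is estimated at 50000 nM, within 20000 nM to 150000 nM, with a high chance that only a limit is reported.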

Compound 4, half-maximal inhibitory concentration: > 50000 nM
Compound 4 gave a limit, no number (the forecaster's own chance of this, stated with the estimate: 85%); the middle value sits exactly at the limit.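

In this assay compound 4 gives > 50000 nM, a limit and not a number. Its steps from compound 1, compound 2 and compound 3 cannot be read: the limit of > 50000 nM in this assay, at which 4 of the 4 values shown sit.

The compounds shown leave open whether any aryl group on the aromatic nitrogen of the shared core brings a value within range in this assay.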